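The compounds below may be only part of what the source reports. "The series", "measured", "known", "first", "only" and "open" are said of these compounds alone.

Of the compounds shown here, three have been read so far in a functional assay on A549 cells (Homo sapiens) for inhibition; on this read-out lower numbers stand for stronger inhibition and higher numbers for weaker inhibition. Compound 1 `O=S(=O)(c1ccccc1)n1ccc2cc(/C=C/c3ccc4ccccc4c3)ccc21` gives > 5000 nM, which is a limit of the assay. Compound 2 `COc1cc(/C=C/c2ccc3c(ccn3S(=O)(=O)c3ccccc3)c2)cc(OC)c1OC` gives > 5000 nM, also a limit. Compound 3 `COc1cc(/C=C\c2ccc3c(ccn3S(=O)(=O)c3ccccc3)c2)cc(OC)c1OC` gives > 5000 nM, again a limit. Compound 3 therefore has no number of its own, and its standing in the series is the limit of > 5000 nM in this assay, at which 3 of the 3 values shown sit. Within the data shown here, the one measured step rests on (the fact that compounds 2 and 3 differ only in the configuration as drawn), and it is a step that the two limits leave unreadable from compound 2 to compound 3.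

Compound 4 `COc1cc(/C=C\c2ccc3c(ccn3C)c2)cc(OC)c1OC` keeps the rest of compound 3 and carries methyl in place of phenylsulfonyl on an aromatic nitrogen. Among the measured compounds shown here, all three measured compounds carry phenylsulfonyl there, so no measured step touches this position and no size can be carried over from the series.

Compound 3, at the limit of > 5000 nM, leaves room for a readable change only toward stronger inhibition, so a step in that direction is expected. Its size is poorly constrained, and a result that stays at the limit remains possible. The expected step, an estimate only, is an at least 16-fold lower number from compound 3 to compound 4 (1.22 log units; beyond the scatter). For compound 4 the estimated value is 300 nM, with an expected range of 10 nM to 5000 nM.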

Compound 4, half-maximal inhibitory concentration: 470 nM
The estimate for compound 4 lay 1.6-fold (0.19 log units) below the measured number; low and high end bracket the measured number.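

In this assay, the aromatic nitrogen of the five-membered aromatic ring is the one position shown where a change gives a readable step: methyl in place of phenylsulfonyl yields an at least 10-fold lower number from compound 3 to compound 4 (1.02 log units; beyond the scatter). Compound 4 is thus the only compound shown with a number of its own, and the step shows that the phenylsulfonyl group on this nitrogen is not required for inhibition on this read-out. On these data alone, the true size of the step remains unknown, and the printed size is only a minimum, because compound 3 has a limit rather than a number: the limit of > 5000 nM in this assay, at which 3 of the 4 values shown sit.

The step from compound 2 to compound 3 cannot be read, so the weight of the double-bond configuration stays open, and with methyl on the aromatic nitrogen it has no readable pair in the compounds shown. Also open, as far as these compounds go, is how much of the step belongs to methyl itself and how much to the loss of phenylsulfonyl, a question that hydrogen on this nitrogen, ethyl, a longer chain or a chain ending in an amine would address.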